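Adding propanoyloxy to the side chain of compound 1

A few compounds are considered here, and "the series" means these few. Any claim that something is new, unique, unknown or untested is made for them only; others in the source may bear on it.

Compound 1 `C=C1CC[C@@H]2[C@](C)(COC(=O)CC)[C@H](OC(=O)CC)CC[C@@]2(C)[C@@H]1CCc1ccoc1`: 94200 nM
Compound 2 `C=C1[C@H](O)C[C@@H]2[C@](C)(COC(=O)CC)[C@H](OC(=O)CC)CC[C@@]2(C)[C@@H]1CCc1ccoc1`: 27700 nM

In a functional assay on NP14 cells (Homo sapiens) for cytotoxicity, read by MTT assay, with a stated time of 48 h (on this read-out higher numbers stand for weaker inhibition and lower numbers for stronger inhibition), compound 1, at 94200 nM, holds the higher of the two numbers. Compound 3 `C=C1CC[C@@H]2[C@](C)(COC(=O)CC)[C@H](OC(=O)CC)CC[C@@]2(C)[C@@H]1CC(OC(=O)CC)c1ccoc1` differs from it by propanoyloxy in place of hydrogen on a saturated chain carbon bound to an aromatic carbon and a saturated chain carbon, on a saturated chain carbon bound to an aromatic carbon and a saturated chain carbon. Within the data shown here, only one measured step bears on this, and only loosely: a 3.4-fold lower number from compound 1 to compound 2 (0.53 log units; beyond the scatter), a modest change from hydroxy in place of hydrogen on a saturated ring carbon. A similarly modest move toward a lower number is therefore expected, with little certainty. The expected step is a 1.7-fold lower number from compound 1 to compound 3 (0.23 log units; within the scatter). For compound 3 the estimated value is 55000 nM, within a range of 20000 nM to 130000 nM.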

Compound 3, half-maximal inhibitory concentration: 43100 nM
The estimate for compound 3 lay 1.3-fold (0.11 log units) above the measured number, and the stated range covers the measured number.
By their numbers in this assay, from the lowest: compounds 2 and 3 (each within the scatter of the next); then compound 1.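

In this assay, the side chain also responds to substitution: placing propanoyloxy on the saturated chain carbon bound to an aromatic carbon and a saturated chain carbon gives a 2.2-fold lower number from compound 1 to compound 3 (0.34 log units; beyond the scatter), a modest step beyond the scatter. So this chain carbon accepts a propanoyloxy group without loss of activity, and the number moves in the same direction as with the ring hydroxy of compound 2. No evidence is available to explain this step.

From the compounds shown here alone, whether the ester matters as such remains open, since an amine at this carbon would test a different group there. A butanoyloxy group, with its longer chain, would show whether the length of the ester chain counts.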